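The source may report more compounds than this note shows. Statements on the series, on what has been measured and on what is new or still open speak of the compounds shown alone.

Measured in a functional assay on A549 cells (Homo sapiens) for antiproliferative activity, read by MTT assay, with a stated time of 72 h (on this read-out lower numbers stand for stronger inhibition and higher numbers for weaker inhibition), so far:
Compound 1 `O=C(Nc1ccc(Nc2nccc(NC3CCCCC3)n2)cc1)Nc1ccc(Cl)c(C(F)(F)F)c1` gives 7430 nM
Compound 2 `O=C(Nc1ccc(Nc2nccc(NC3CCCC3)n2)cc1)Nc1ccc(Cl)c(C(F)(F)F)c1` gives 5880 nM
Compound 3 `Cn1cc(Nc2ccnc(Nc3ccc(NC(=O)Nc4ccc(Cl)c(C(F)(F)F)c4)cc3)n2)cn1` gives 8610 nM

Compound 2 at 5880 nM cannot be separated from the other two compounds. The step of a 1.3-fold lower number from compound 1 to compound 2 (0.10 log units; within the scatter) lies within the scatter, and so do a 1.5-fold higher number from compound 2 to compound 3 (0.17 log units; within the scatter) and a 1.2-fold higher number from compound 1 to compound 3 (0.06 log units; within the scatter) as well.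

Compound 4 `O=C(Nc1ccc(Nc2nccc(NC3CCCC3)n2)cc1)Nc1cccc(C(F)(F)F)c1` differs from compound 2 at a different place: hydrogen in place of chloro on an aromatic carbon turns 4-chloro-3-(trifluoromethyl)phenyl into 3-(trifluoromethyl)phenyl, with hydrogen in place of chloro on an aromatic carbon. All three measured steps exchange the group on a nitrogen, and none touches the chloro, so they bear on this change only indirectly. The data hold no direct measure of it. A small move towards a higher number in this assay is expected, with little confidence in its direction, and nothing beyond the scatter. The expected change is a 1.4-fold higher number from compound 2 to compound 4 (0.13 log units; within the scatter) and remains an estimate. Compound 4 is estimated at 8000 nM with an expected range from 3500 nM to 18000 nM in this read-out.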

Compound 4, half-maximal inhibitory concentration: 4900 nM
The estimate for compound 4 lay 1.6-fold (0.21 log units) above the measured number; low and high end bracket the measured number.
By their numbers in this assay, from the lowest: compounds 4, 2, 1 and 3 (each within the scatter of the next).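

The earlier steps shown here all exchanged the group on a nitrogen, whereas this one falls on the six-membered aromatic ring of carbon only, on the carbon ortho to a trifluoromethyl group and para to a large group. Hydrogen in place of chloro there gives a 1.2-fold lower number from compound 2 to compound 4 (0.08 log units; within the scatter) in this assay, so with cyclopentyl on the nitrogen, 4-chloro-3-(trifluoromethyl)phenyl and 3-(trifluoromethyl)phenyl cannot be told apart in this read-out and the chloro is not needed to keep the number at this level. Nothing at hand explains this result.

On these data alone, it remains open whether the exchange reads the same with cyclohexyl or 1-methyl-1H-pyrazol-4-yl on the nitrogen, and whether a methoxy group, a nitrile or an amine on this carbon would move the number beyond the scatter. As far as these compounds go, the part played by the trifluoromethyl group, present in all four compounds, also stays open.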